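Compound 2 to compound 3: a cyclopropylamino step

A few compounds are considered here, and "the series" means these few. Any claim that something is new, unique, unknown or untested is made for them only; others in the source may bear on it.

In a functional assay on PC-3 cells (Homo sapiens) for cytotoxicity, read by sulforhodamine B assay, with a stated time of 72 h (on this read-out lower numbers stand for stronger inhibition and higher numbers for weaker inhibition), compound 1 (`Nc1nc(O)c2ncn([C@@H]3C(F)=C(CO)[C@@H](O)[C@H]3O)c2n1`) gives > 100000 nM as a limit. Among the compounds with values here, compound 2 (`Nc1nc(N)c2ncn([C@@H]3C(F)=C(CO)[C@@H](O)[C@H]3O)c2n1`) gives > 100000 nM as a limit too, so it offers no number to start from. the limit of > 100000 nM in this assay, at which 2 of the 2 values shown sit, sums up the series so far. Compound 3 (`Nc1nc(NC2CC2)c2ncn([C@@H]3C(F)=C(CO)[C@@H](O)[C@H]3O)c2n1`) differs from compound 2 by cyclopropyl in place of hydrogen on a nitrogen on an aromatic ring and so reads amino to cyclopropylamino. Within the data shown here, with a step that the two limits leave unreadable from compound 1 to compound 2 as the only measured step, no size carries over and no step beyond the scatter is expected in this assay in either direction. The estimate means a number no higher from compound 2 to compound 3 (the limit leaves the size open) as the expected step. Compound 3 is estimated at 100000 nM with an expected range from 30000 nM to 300000 nM in this assay.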

Compound 3, half-maximal inhibitory concentration: > 100000 nM
Compound 3: a limit, no number; the forecaster's own chance of this, stated with the estimate: 75%; the middle value lies on the limit itself.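

In this assay compound 3 gives > 100000 nM, a limit and not a number, so the steps to compound 3 from compound 1 and compound 2 cannot be read. Left open is how the three compounds compare with one another, as all share one limit: the limit of > 100000 nM in this assay, at which 3 of the 3 values shown sit.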